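Removing the benzyl ester from two nitroaryl diaminopyrimidines

The source may hold more compounds than are shown below. What is called first, only, known or untested is meant among the compounds shown, and "the series" means these compounds.

Compound 1 `COC(=O)c1ccc(CN(CCCc2c(N)nc(N)nc2O)c2cc(F)cc(F)c2[N+](=O)[O-])cc1` and compound 2 `COC(=O)c1ccc(CN(CCCc2c(N)nc(N)nc2O)c2cc(F)c([N+](=O)[O-])cc2[N+](=O)[O-])cc1` share a core; the difference between the two cores is not broken down here. In a functional assay on CCRF-CEM cells (Homo sapiens) for cytotoxicity, in the presence of a further agent that is not named here (a higher number here means a weaker inhibitor, a lower number a stronger inhibitor), compound 1 gives only a limit, > 100000 nM. Compound 2 gives 3500 nM, the lowest of the two numbers obtained so far. Compound 3 `Nc1nc(N)c(CCCNc2cc(F)cc(F)c2[N+](=O)[O-])c(O)n1` carries the change hydrogen in place of 4-(methoxycarbonyl)benzyl on a nitrogen on an aromatic ring and gives 94000 nM, which is an at least 1.0-fold lower number from compound 1 to compound 3 (0.02 log units; that floor lies within the scatter). That step starts from the limit of compound 1 (the limit of > 100000 nM in this assay, at which 1 of the 3 values shown sits). Compound 4 `Nc1nc(N)c(CCCNc2cc(F)c([N+](=O)[O-])cc2[N+](=O)[O-])c(O)n1` carries the same change, (hydrogen in place of 4-(methoxycarbonyl)benzyl on a nitrogen on an aromatic ring), on the core of compound 2. Beside the earlier step, compound 4 is expected to move a 1.1-fold higher number from compound 2 to compound 4 (0.06 log units; within the scatter), an expectation that rests on compound 2 giving 3500 nM and on the step of an at least 1.0-fold lower number from compound 1 to compound 3 (0.02 log units; that floor lies within the scatter) being flat. Compound 4 is therefore estimated at 4000 nM, between 800 nM and 20000 nM.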

Compound 4, half-maximal inhibitory concentration: 1200 nM
Compound 4: middle estimate off by 3.3-fold (0.52 log units), on the high side, and the stated range covers the measured number.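

On the core of compound 2, hydrogen in place of 4-(methoxycarbonyl)benzyl gives in this assay a 2.9-fold lower number from compound 2 to compound 4 (0.46 log units; beyond the scatter). Whether this step carries over unchanged from one core to the other is not shown: the same change on two cores in this assay, an at least 1.0-fold lower number (0.02 log units; that floor lies within the scatter) from compound 1 to compound 3 and a 2.9-fold lower number (0.46 log units; beyond the scatter) from compound 2 to compound 4; the limit leaves it open whether they differ. Compound 1, the starting point of the other step, gives a limit and not a number: the limit of > 100000 nM in this assay, at which 1 of the 4 values shown sits.

The whole 4-(methoxycarbonyl)benzyl group leaves in a single step, so the compounds shown do not separate the contribution of the ester from that of the ring carrying it. From the compounds shown here alone, whether an unsubstituted benzyl, or a benzyl bearing a carboxylic acid in place of the ester, on that nitrogen would fall with compound 2 or with compound 4 remains open.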